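Adding a Second Fluorine to a Series Without Measurable Activity

This account rests on a few compounds, and the source may have more. Where it says the series, first, only, none or still open, it means among the compounds named here.

Compound 1 `COc1cc(-c2nnc(SCc3ccccc3)n2N2C(=O)c3ccccc3C2=O)cc(OC)c1OC` gives > 200000 nM in a functional assay on PC-3M cells (Homo sapiens) for cytotoxicity, read by MTT assay, with a stated time of 48 h (on this read-out lower numbers stand for stronger inhibition and higher numbers for weaker inhibition), which is a limit of the assay.
Compound 2 `COc1cc(-c2nnc(SCC(=O)c3ccccc3)n2N2C(=O)c3ccccc3C2=O)cc(OC)c1OC` gives > 200000 nM in this assay, again a limit.
Compound 3 `COc1cc(-c2nnc(SCC(=O)c3ccc(F)cc3)n2N2C(=O)c3ccccc3C2=O)cc(OC)c1OC` gives > 200000 nM in this assay, also a limit.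

Compound 3 thus stands at the limit in this assay, with no number of its own. The three measured steps give no guidance on size: the step that the two limits leave unreadable from compound 1 to compound 2, the step that the two limits leave unreadable from compound 1 to compound 3 and the step that the two limits leave unreadable from compound 2 to compound 3 all remain unreadable, since both ends of each sit at the limit.

Compound 4 `COc1cc(-c2nnc(SCC(=O)c3ccc(F)c(F)c3)n2N2C(=O)c3ccccc3C2=O)cc(OC)c1OC` differs from compound 3 by fluoro in place of hydrogen on an aromatic carbon. For the measured compounds named here, no measured step bears on this change in a readable way. What the series does show is the limit of > 200000 nM in this assay, at which 3 of the 3 values shown sit, and nothing in the shown values suggests that a second fluoro group would move compound 4 off that limit.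

Compound 4 is therefore expected to show a step that the limit leaves unreadable from compound 3 to compound 4 in this assay, meaning no readable change. Compound 4 is estimated at 300000 nM in this assay, with a range from 100000 nM to 1000000 nM, most likely reported only as a limit.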

Compound 4, half-maximal inhibitory concentration: 163000 nM
Estimate against measurement, compound 4: 1.8-fold (0.26 log units) above; measured number inside the range.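

For the compounds shown here, with the 3,4-difluorophenyl group, the series gains its first number rather than a limit in this assay, so the change of fluoro in place of hydrogen, ortho to a fluoro group, is the first to give a step with a readable floor: an at least 1.2-fold lower number from compound 3 to compound 4 (0.08 log units; that floor lies within the scatter). The wider changes give an at least 1.2-fold lower number from compound 2 to compound 4 (0.08 log units; that floor lies within the scatter) and also an at least 1.2-fold lower number from compound 1 to compound 4 (0.08 log units; that floor lies within the scatter) in this reading, and since each floor lies within the scatter, no real gain can be claimed. Compound 4 is the only compound shown that stands off the limit: the limit of > 200000 nM in this assay, at which 3 of the 4 values shown sit.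

From the compounds shown here alone, the true size of these steps stays open, and the steps among compound 1, compound 2 and compound 3 cannot be read. Also open, going by these compounds, is what an amine or a carboxylic acid at this place on the aromatic ring would give.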